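From 3-(dimethylamino)propyl to propanoyl on a shared core

The source may hold more compounds than are shown below. What is called first, only, known or untested is meant among the compounds shown, and "the series" means these compounds.

- compound 1 `COc1ccc(/C=C/C(=O)c2ccc(OC)c3c2OC(C)(C)C=C3)cc1OCC=C(C)C` gives > 10000 nM (a limit)
- compound 2 `COc1ccc(/C=C/C(=O)c2ccc(OC)c3c2OC(C)(C)C=C3)cc1OCCO` gives > 10000 nM (a limit)
- compound 3 `COc1ccc(/C=C/C(=O)c2ccc(OC)c3c2OC(C)(C)C=C3)cc1OCCCN(C)C` gives 8600 nM

Within the data shown here, in an ADME assay on L02 cells (Homo sapiens) for cytotoxicity, read by MTT assay (a higher number here means a weaker inhibitor, a lower number a stronger inhibitor), compound 3 gives 8600 nM, the only true number of the three. Compound 1 reads > 10000 nM, which is a limit of the assay and not a number. Compound 2 reads > 10000 nM, again a limit. The two together form (the limit of > 10000 nM in this assay, at which 2 of the 3 values shown sit).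

The next compound to be tested is compound 4 `CCC(=O)Oc1cc(/C=C/C(=O)c2ccc(OC)c3c2OC(C)(C)C=C3)ccc1OC`. It keeps the shared core, and its change from compound 3 is propanoyl in place of 3-(dimethylamino)propyl on an oxygen on an aromatic ring.

Among the measured compounds shown here, no measured step makes this exact change, but two come close, as each swaps the chain on that same oxygen: an at least 1.1-fold lower number from compound 1 to compound 3 (0.06 log units; that floor lies within the scatter) and an at least 1.1-fold lower number from compound 2 to compound 3 (0.06 log units; that floor lies within the scatter). Both are only floors and stay within the scatter, so they show no firm effect of the 3-(dimethylamino)propyl chain. Like compound 1 and compound 2, compound 4 lacks that chain, so a reading close to the limit seems likely.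

The expected change is a 1.3-fold higher number from compound 3 to compound 4 (0.11 log units; within the scatter), and no step beyond the scatter is expected. Compound 4 is expected at about 11000 nM, with an estimated range from 6000 nM to 25000 nM.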

Compound 4, half-maximal inhibitory concentration: > 10000 nM
Compound 4 was reported as a limit; the forecaster's own chance of this, stated with the estimate: 65%; the middle value lies beyond the limit too.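

In this assay, compound 4 is the first shown with a carbonyl group, propanoyl, bound directly to an oxygen on an aromatic ring, where compounds 1, 2 and 3 carry saturated chain carbons. Replacing 3-(dimethylamino)propyl with propanoyl gives an at least 1.1-fold higher number from compound 3 to compound 4 (0.06 log units; that floor lies within the scatter), so even this different kind of attachment produces no step beyond the scatter, and the dimethylamino chain of compound 3 still cannot be said to raise or lower the number. Among these compounds, the value of compound 4 is a limit, and it adds a third group to those that reach the same reading, with compound 3 the one exception as the only true number: the limit of > 10000 nM in this assay, at which 3 of the 4 values shown sit.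

On these data alone, the steps from compound 1 and from compound 2 to compound 4 cannot be read, as both ends of each are limits, so how far these three compounds truly differ stays unknown. Also open, as far as these compounds go, is whether a carboxylic acid or a longer chain ending in an amine on this oxygen would give a number clearly apart from that of compound 3.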